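Ester Variation on a Piperazine Core and Vero Cell Toxicity

The source may report more compounds than this note shows. Statements on the series, on what has been measured and on what is new or still open speak of the compounds shown alone.

Measured compounds:
compound 1 `O=C(OC1CCC(CN2CCN(c3cc(=O)c4cc(C(F)(F)F)cc([N+](=O)[O-])c4s3)CC2)CC1)C1CCC1` — > 64 ug/mL
compound 2 `COc1ccccc1C(=O)OC1CCC(CN2CCN(c3cc(=O)c4cc(C(F)(F)F)cc([N+](=O)[O-])c4s3)CC2)CC1` — > 64 ug/mL
compound 3 `CCCC(=O)OC1CCC(CN2CCN(c3cc(=O)c4cc(C(F)(F)F)cc([N+](=O)[O-])c4s3)CC2)CC1` — > 64 ug/mL

In an ADME assay on Vero cells (Chlorocebus sabaeus) for cytotoxicity, read by MTT assay, with a stated time of 48 h (a lower number here means a stronger inhibitor, a higher number a weaker inhibitor), compound 1 gives a limit, not a number. The same holds for compound 2, and for compound 3. Because all three sit at the limit of > 64 ug/mL in this assay, at which 3 of the 3 values shown sit, nothing can be read about the size of the steps among them: a step that the two limits leave unreadable from compound 1 to compound 2, a step that the two limits leave unreadable from compound 1 to compound 3 and a step that the two limits leave unreadable from compound 2 to compound 3 all stay unreadable.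

Compound 4 `O=C(OC1CCC(CN2CCN(c3cc(=O)c4cc(C(F)(F)F)cc([N+](=O)[O-])c4s3)CC2)CC1)c1ccc(F)cc1` has not yet been tested in this assay. It differs from compound 1 by 4-fluorophenyl in place of cyclobutyl on a carbonyl carbon. The measured steps all concern the same carbonyl carbon, swapping cyclobutyl for propyl or for 2-methoxyphenyl, and none of them moved the read-out off the limit. The step to compound 4 is therefore expected to be a step that the limit leaves unreadable from compound 1 to compound 4, that is none beyond the scatter, with the result most likely again a limit rather than a number. The estimate for compound 4 in this assay is 80 ug/mL, between 40 ug/mL and 200 ug/mL.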

Compound 4, half-maximal inhibitory concentration: > 64 ug/mL
Compound 4: no number, only a limit; the forecaster's own chance of this, stated with the estimate: 85%; the middle value is on the limit's open side.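

In this assay, compound 4 gives only a limit, so its steps to compound 1, compound 2 and compound 3 cannot be read: the limit of > 64 ug/mL in this assay, at which 4 of the 4 values shown sit. The compounds shown leave open what actual number any of the four would give, and whether any group on this carbonyl carbon moves the read-out off the limit.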